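This account rests on a few compounds, and the source may have more. Where it says the series, first, only, none or still open, it means among the compounds named here.

Compounds measured in a functional assay on BJAB cells (Homo sapiens) for antiproliferative activity, with a stated time of 4 days; on this read-out higher numbers stand for an effect only at larger amounts of compound and lower numbers for an effect already at smaller amounts:
compound 1 `COC(=O)c1c(Cc2ccccc2[N+](=O)[O-])c(C)nn1-c1nc(-c2ccc(Cl)c(Cl)c2)cs1` gives 377000 nM
compound 2 `Cc1nn(-c2nc(-c3ccc(Cl)c(Cl)c3)c(SC(C)C)s2)c(C(=O)O)c1-c1cnccn1` gives 14000 nM
compound 3 `COC(=O)c1c(Cc2ccccc2[N+](=O)[O-])c(C)nn1-c1nc(-c2ccc(Cl)c(Cl)c2)c(SC(C)C)s1` gives 93000 nM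

Compound 2 stands lowest of the three numbers in this assay; compound 3 is nearest, compound 1 furthest, both beyond the scatter.

Compound 4 `Cc1nn(-c2nc(-c3ccc(Cl)c(Cl)c3)c(SC(C)C)s2)c(C(=O)O)c1-c1ccccc1C(F)(F)F` differs from compound 2 in one place: 2-(trifluoromethyl)phenyl in place of pyrazin-2-yl on an aromatic carbon. Going by the values given here, the only measured single step, a 4.1-fold lower number from compound 1 to compound 3 (0.61 log units; beyond the scatter), concerns isopropylsulfanyl on the other ring and does not touch the position changed here; no step with pyrazin-2-yl against a phenyl group has been measured. The expectation therefore rests on compound 2 alone, with wide uncertainty: a step of a 1.4-fold higher number from compound 2 to compound 4 (0.15 log units; within the scatter) is expected, not beyond the scatter. Compound 4 is estimated at 20000 nM (range 5000 nM to 80000 nM).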

Compound 4, half-maximal effective concentration: 5200 nM
For compound 4 the middle estimate is 3.8-fold (0.59 log units) above the measured one, within the range that was stated.
By their numbers in this assay, from the lowest: compound 4; then compound 2; then compound 3; then compound 1.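

In this assay, the position next to the ring atom that bears a carboxy group is sensitive to the aromatic group it carries: 2-(trifluoromethyl)phenyl in place of pyrazin-2-yl gives a 2.7-fold lower number from compound 2 to compound 4 (0.43 log units; beyond the scatter). A six-membered aromatic ring of carbon only, with no hydrogen-bond acceptors, is therefore tolerated here, with a modest shift toward lower numbers. No supporting data point to a cause for this step.

On these data alone, a plain phenyl group would separate the part played by the trifluoromethyl group from that of the carbon-only ring, so this remains open. Also open, as far as these compounds go, is how an amide in place of the carboxy group would read out alongside the 2-(trifluoromethyl)phenyl group.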